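This account rests on a few compounds, and the source may have more. Where it says the series, first, only, none or still open, it means among the compounds named here.

Of the compounds shown here, three sharing one core have been measured in an assay on isolated protein for inhibition of protein deacetylase HDAC6 (Homo sapiens), read by fluorescence, with stated times of 15 min and 30 min; on this read-out lower numbers stand for stronger inhibition and higher numbers for weaker inhibition. Compound 1 `O=C(NO)c1ccc(Cn2[se]c3ccccc3c2=O)cc1`, which carries a hydrogen at the varied position, gives 37 nM. Compound 2 `O=C(NO)c1ccc(Cn2[se]c3ccc(F)cc3c2=O)cc1` gives 178 nM, and compound 3 `O=C(NO)c1ccc(Cn2[se]c3ccc(O)cc3c2=O)cc1` gives 188 nM. Compound 3 thus holds the highest number of the three, though its distance to compound 2 is within the scatter, as the step of a 1.1-fold higher number from compound 2 to compound 3 (0.02 log units; within the scatter) shows. Against compound 1 the distance is real: a 5.1-fold higher number from compound 1 to compound 3 (0.71 log units; beyond the scatter), and the parallel step a 4.8-fold higher number from compound 1 to compound 2 (0.68 log units; beyond the scatter) is of about the same size.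

Compound 4 `O=C(NO)c1ccc(Cn2[se]c3ccc(C(F)(F)F)cc3c2=O)cc1` arises from compound 3 by one change: trifluoromethyl in place of hydroxy on an aromatic carbon. Within the data shown here, the steps that bear on it show that two different groups placed at this position, fluoro and hydroxy, both gave similar numbers a little higher than hydrogen, and that swapping one for the other changed little. A third group at the same position is therefore expected to land near compound 2 and compound 3, with a step from compound 3 of a 1.0-fold lower number from compound 3 to compound 4 (0.02 log units; within the scatter), that is, no step beyond the scatter. Compound 4 is estimated to give 180 nM in this assay, within the range 60 nM to 550 nM.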

Compound 4, half-maximal inhibitory concentration: 584 nM
Compound 4: the middle estimate sits 3.2-fold (0.51 log units) below what was measured; the measured number lies above the stated range.
By their numbers in this assay, from the lowest: compound 1; then compounds 2 and 3 (each within the scatter of the next); then compound 4.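

The position does not hold every group at one level: in this assay trifluoromethyl stands apart from both earlier substituents, with a 3.1-fold higher number from compound 3 to compound 4 (0.49 log units; beyond the scatter) and a 3.3-fold higher number from compound 2 to compound 4 (0.52 log units; beyond the scatter), while fluoro and hydroxy remained within the scatter of each other. Replacing hydrogen is thus far more costly with this group than the earlier compounds indicated, as shown by a 16-fold higher number from compound 1 to compound 4 (1.20 log units; beyond the scatter), and compound 1 keeps the lowest number of the four. Nothing available explains why trifluoromethyl departs from fluoro and hydroxy here.

From the compounds shown here alone, how a methyl, a methoxy, an amine or a carboxylic acid would read at this position remains open. So does whether trifluoromethyl would give a similar step on another aromatic carbon of the shared core.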